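Chromone ethers with basic side chains at the sigma-1 receptor

The source may report more compounds than this note shows. Statements on the series, on what has been measured and on what is new or still open speak of the compounds shown alone.

Compound 1 `O=c1cc(-c2ccccc2)oc2cccc(OCCCN3CCC(O)CC3)c12`: 91 nM
Compound 2 `O=c1cc(-c2ccccc2)oc2cccc(OCCCCCCCN3CCC(O)CC3)c12`: 65 nM
Compound 3 `CN(C)CCCCCCCCCCOc1ccc2oc(-c3ccccc3)cc(=O)c2c1`: 341 nM

In an assay on isolated protein (Cavia porcellus) with Sigma non-opioid intracellular receptor 1 (Homo sapiens) as the target, read by radioligand binding (a lower number here means a stronger inhibitor, a higher number a weaker inhibitor), compound 3 gives the highest number of the three measured compounds, standing beyond the scatter from compound 1 and further still from compound 2. Compound 4 `O=c1cc(-c2ccccc2)oc2ccc(OCCCCCCN3CCNC(CCO)C3)cc12` has not yet been measured. It differs from compound 3 in one place: 3-(2-hydroxyethyl)piperazin-1-yl in place of 4-(dimethylamino)butyl on a saturated chain carbon, six bonds along the chain from an oxygen on an aromatic ring. Among the compounds with values here, no step between measured compounds shares this change, so the expectation rests on the shared core and the hydroxyl-bearing ring amines of compounds 1 and 2. The estimated step of a 1.9-fold lower number from compound 3 to compound 4 (0.28 log units; within the scatter) is expected to be a modest move toward a lower number, possibly within the scatter. For compound 4 the estimate is 180 nM, with a range from 50 nM to 700 nM.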

Compound 4, half-maximal inhibitory concentration: 94 nM
Beside the measured number, compound 4's estimate is 1.9-fold (0.28 log units) above it; low and high end bracket the measured number.
By their numbers in this assay, from the lowest: compounds 2, 1 and 4 (each within the scatter of the next); then compound 3.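

In this assay, 3-(2-hydroxyethyl)piperazin-1-yl in place of 4-(dimethylamino)butyl on a saturated chain carbon, six bonds along the chain from an oxygen on an aromatic ring, gives a 3.6-fold lower number from compound 3 to compound 4 (0.56 log units; beyond the scatter) and so lies beyond the scatter. This is the only single change that can be read among these compounds, and it shows that this position tolerates the larger ring amine with no rise in the number. Nothing measured here accounts for the step.

As far as these compounds go, it remains open whether the piperazine ring or its 2-hydroxyethyl group carries the step, which an unsubstituted piperazine would test. From the compounds shown here alone, whether a morpholine or a longer chain would keep the lower number also remains open.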